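Three Measured Compounds and One Still Awaiting Its Number

This account rests on a few compounds, and the source may have more. Where it says the series, first, only, none or still open, it means among the compounds named here.

Three compounds that share one core and differ only in a single group on the attached six-membered ring have been measured in an assay for binding affinity to adenosine receptor A1 (Bos taurus); a lower number here means a stronger inhibitor, a higher number a weaker inhibitor. Compound 1 `Cn1c(=O)c2nc(-c3cccc([N+](=O)[O-])c3)[nH]c2n(C)c1=O` carries a nitro group and gives 50 nM. Compound 2 `Cn1c(=O)c2nc(-c3cccc(N)c3)[nH]c2n(C)c1=O` carries an amino group in its place and gives 10 nM. Compound 3 `Cc1cccc(-c2nc3c(=O)n(C)c(=O)n(C)c3[nH]2)c1` carries a methyl group there and gives 13 nM. Among these three numbers compound 3 stands second highest: a 1.3-fold higher number from compound 2 to compound 3 (0.11 log units; within the scatter), while a 3.8-fold lower number from compound 1 to compound 3 (0.59 log units; beyond the scatter). Compound 4 `CN(C)c1cccc(-c2nc3c(=O)n(C)c(=O)n(C)c3[nH]2)c1` differs from compound 3 in one place: dimethylamino in place of methyl on an aromatic carbon. Going by the values given here, the step that bears most directly on this change is the one between compound 2 and compound 3, since both amino and dimethylamino are groups built on nitrogen, and that step lay within the scatter. The larger steps both involve the nitro group, which compound 4 does not carry. One of them is this: a 5.0-fold lower number from compound 1 to compound 2 (0.70 log units; beyond the scatter). The other, from compound 1 to compound 3, likewise lies beyond the scatter. No step beyond the scatter is therefore expected in this assay for compound 4. Compound 4 is estimated at 12 nM, within a range from 5 nM to 30 nM. The expected step is a 1.1-fold lower number from compound 3 to compound 4 (0.03 log units; within the scatter).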

Compound 4, half-maximal inhibitory concentration: 80 nM
The estimate for compound 4 lay 6.7-fold (0.82 log units) below the measured number; the whole stated range lies below it.
By their numbers in this assay, from the lowest: compounds 2 and 3 (each within the scatter of the next); then compounds 1 and 4 (each within the scatter of the next).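

In this assay, going by these compounds alone, the earlier compounds left nitro as the only group at this place on the ring that stood apart, and dimethylamino now joins it, with a 1.6-fold higher number from compound 1 to compound 4 (0.20 log units; within the scatter). Nitrogen alone therefore does not keep the number low here: putting dimethylamino in place of methyl gives a 6.2-fold higher number from compound 3 to compound 4 (0.79 log units; beyond the scatter), and putting it in place of amino gives an 8.0-fold higher number from compound 2 to compound 4 (0.90 log units; beyond the scatter), although amino and methyl themselves could not be told apart. Nothing available here explains why amino and dimethylamino differ so clearly.

On these data alone, it remains open whether methylamino, which lies between amino and dimethylamino in its count of methyl groups, would stay with amino or fall with dimethylamino. As far as these compounds go, it is also open where a larger group on nitrogen, such as diethylamino or an acetamide, would land.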